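A few compounds are considered here, and "the series" means these few. Any claim that something is new, unique, unknown or untested is made for them only; others in the source may bear on it.

All three measured compounds were tested in a functional assay on SGC-7901 cells (Homo sapiens) for antiproliferative activity, read by MTT assay, with a stated time of 72 h; a lower number here means a stronger inhibitor, a higher number a weaker inhibitor:

- compound 1, `COc1ccc(-c2sc(C(=O)O)cc2-c2cc(OC)c(OC)c(OC)c2)cc1[N+](=O)[O-]`, gives 23300 nM
- compound 2, `COc1ccc(-c2sc(C(=O)O)cc2-c2cc(OC)c(OC)c(OC)c2)cc1OCc1ccccc1`, gives > 100000 nM
- compound 3, `COc1ccc(-c2cc(C(=O)O)sc2-c2cc(OC)c(OC)c(OC)c2)cc1[N+](=O)[O-]`, gives 21600 nM

Compound 1 and compound 3 are built from the same atoms, joined differently; the difference between their two cores is not broken down here. Their two values sit within the usual scatter of each other, so no order between compound 1 and compound 3 can be read from them.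

The value of compound 2 is a limit of this assay, not a number, as shown by the limit of > 100000 nM in this assay, at which 1 of the 3 values shown sits. Going from compound 1 to compound 2 brings one change, (benzyloxy in place of nitro on an aromatic carbon), and this change gives an at least 4.2-fold higher number from compound 1 to compound 2 (0.63 log units; beyond the scatter).

Compound 4, `COc1ccc(-c2cc(C(=O)O)sc2-c2cc(OC)c(OC)c(OC)c2)cc1OCc1ccccc1`, is not yet measured. It stands to compound 3 as compound 2 stands to compound 1: the change is benzyloxy in place of nitro on an aromatic carbon, and the place is the same word for word as in the first pair, so this is the same change. Because the same change gave an at least 4.2-fold higher number from compound 1 to compound 2 (0.63 log units; beyond the scatter), a step of similar size is expected from compound 3 to compound 4, namely a 5.6-fold higher number from compound 3 to compound 4 (0.74 log units; beyond the scatter). On that ground compound 4 is expected to give about 120000 nM in this assay, most likely between 50000 nM and 300000 nM, with a fair chance that only a limit is reported.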

Compound 4, half-maximal inhibitory concentration: > 100000 nM
Compound 4 gave a limit, no number (the forecaster's own chance of this, stated with the estimate: 60%); the middle value is on the limit's open side.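

In this assay compound 4 gives > 100000 nM, which is a limit and not a number. On this second core, benzyloxy in place of nitro gives an at least 4.6-fold higher number from compound 3 to compound 4 (0.66 log units; beyond the scatter), so the change moves the result towards a weaker inhibitor on both cores shown, and each step lies beyond the usual scatter. This shows that the direction of the change carries from one core to the other in these two pairs, but it does not show that the size carries over, since neither step has a known upper end: the same change on two cores in this assay, an at least 4.2-fold higher number (0.63 log units; beyond the scatter) from compound 1 to compound 2 and an at least 4.6-fold higher number (0.66 log units; beyond the scatter) from compound 3 to compound 4; the limit leaves it open whether they differ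

The compounds shown hold only nitro and benzyloxy at this place, so it stays open how a group such as an amine, a hydroxyl or a small alkoxy chain would read there, and whether any such group would give a lower number than compound 1 or compound 3. The carboxylic acid is also the same in all four compounds, which leaves open what an ester or an amide in its place would do on either core.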